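Cytotoxicity notes: methyl for chloro on the amide core

The source may hold more compounds than are shown below. What is called first, only, known or untested is meant among the compounds shown, and "the series" means these compounds.

Measured so far:
- compound 1 `Cc1ccc(O)c(C(=O)NCCCCN2[C@H](C)CCC[C@@H]2C)c1` — a functional assay on MDBK cells (Bos taurus) for cytotoxicity; a lower number here means that less compound is tolerated, a higher number that more compound is tolerated: a limit, > 100 ug/mL
- compound 2 `C[C@@H]1CCC[C@H](C)N1CCCNC(=O)c1cc(Cl)ccc1O` — this assay: 30 ug/mL

Within the data shown here, compound 2 carries the only numeric value in this assay; the other value shown is a limit. Compound 1 reaches the assay limit, (the limit of > 100 ug/mL in this assay, at which 1 of the 2 values shown sits), so its two values can only be compared in the sense that compound 2 is tolerated below that limit.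

Compound 3 `Cc1ccc(O)c(C(=O)NCCCN2[C@H](C)CCC[C@@H]2C)c1` is not yet measured. It differs from compound 2 by methyl in place of chloro on an aromatic carbon.

Among the measured compounds shown here, no step between measured compounds is available, so the size of the step from compound 2 to compound 3 is an expectation only. Compound 3 is expected to be tolerated somewhat better than compound 2, a step of a 2.3-fold higher number from compound 2 to compound 3 (0.37 log units; beyond the scatter), because the methyl-bearing compound 1 sits at > 100 ug/mL. For compound 3 the estimate in this assay is 70 ug/mL, with a range from 30 ug/mL to 150 ug/mL, and a fair chance that only a limit is reported.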

Compound 3, half-maximal cytotoxic concentration: > 100 ug/mL
Compound 3: only a limit was reported; the forecaster's own chance of this, stated with the estimate: 45%; at least 1.4-fold (0.15 log units) between middle value and limit.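

The change from chloro to methyl on the aromatic carbon para to a hydroxy group now has a direct reading in this assay, with an at least 3.3-fold higher number from compound 2 to compound 3 (0.52 log units; beyond the scatter). Compound 1 differs from compound 2 in the chain as well as in this group, so it could not separate the two changes, whereas compound 3 keeps the chain of compound 2 and isolates the group on the ring. The size of the step is a floor only, and the real gap cannot be read from it, because compound 3 sits at the assay limit: the limit of > 100 ug/mL in this assay, at which 2 of the 3 values shown sit.

On these data alone, how far compound 3 lies past that limit stays open, and so does whether the chain matters when chloro is on the ring. Also open, as far as these compounds go, is whether a fluoro or methoxy group at this position follows methyl or chloro.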